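Shortening the Alkoxy Chain on a Potent Antagonist

The source may report more compounds than this note shows. Statements on the series, on what has been measured and on what is new or still open speak of the compounds shown alone.

Compound 2 `CCCCCCOc1cc(C(C)(C)C)ccc1CNC(=O)C(C)c1ccc(NS(C)(=O)=O)c(F)c1` gives 0.5 nM in an assay on cells for antagonist activity at transient receptor potential cation channel subfamily V member 1 (Homo sapiens), read by FLIPR and calcium flux, with a stated time of 6 min; a lower number here means a stronger inhibitor, a higher number a weaker inhibitor. Of the two numbers in hand it sits alongside compound 1 `CC1CCN(c2cc(C(C)(C)C)ccc2CNC(=O)C(C)c2ccc(NS(C)(=O)=O)c(F)c2)CC1`, which gives 0.7 nM; the step of a 1.4-fold lower number from compound 1 to compound 2 (0.15 log units; within the scatter) is within the scatter, so the two cannot be told apart. Compound 3 `CC(C)COc1cc(C(C)(C)C)ccc1CNC(=O)C(C)c1ccc(NS(C)(=O)=O)c(F)c1` has not yet been measured. It differs from compound 2 by isopropyl in place of pentyl on a saturated chain carbon bound to an oxygen on an aromatic ring. Among the measured compounds shown here, the only measured step, from compound 1 to compound 2, swapped an entire ring for the hexyloxy group without moving the number beyond the scatter, and it says little about how much the length of the chain itself matters once the oxygen is present. For the measured compounds named here, with no direct precedent, a modest loss is the cautious expectation. The step expected here is a 3.0-fold higher number from compound 2 to compound 3 (0.48 log units; beyond the scatter). Compound 3 is therefore estimated at 1.5 nM, with a likely range from 0.4 nM to 6 nM.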

Compound 3, inhibition constant: 2.1 nM
Beside the measured number, compound 3's estimate is 1.4-fold (0.15 log units) below it; measured number inside the range.
By their numbers in this assay, from the lowest: compounds 2 and 1 (each within the scatter of the next); then compound 3.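

In this assay, the makeup of the alkoxy chain on the shared core does matter: a 4.2-fold higher number from compound 2 to compound 3 (0.62 log units; beyond the scatter) when hexyloxy gives way to isobutoxy, a step beyond the scatter, whereas the earlier exchange of 4-methylpiperidin-1-yl for hexyloxy stayed within it. Isobutoxy also falls short of the ring-bearing 4-methylpiperidin-1-yl group, with a 3.0-fold higher number from compound 1 to compound 3 (0.48 log units; beyond the scatter), so compound 3 is the weakest of the three inhibitors, although both losses are modest. No measurement offered here accounts for these losses.

The change from hexyloxy to isobutoxy shortens the chain and adds a branch in a single step, so the compounds shown cannot separate those two changes. An unbranched butoxy chain would help to tell them apart, while an octyloxy chain would show whether extending the chain beyond hexyloxy changes the number.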